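The source may hold more compounds than are shown below. What is called first, only, known or untested is meant among the compounds shown, and "the series" means these compounds.

Measured so far in an assay on isolated protein for binding affinity to C-X-C chemokine receptor type 3 (Homo sapiens); a higher number here means a weaker inhibitor, a lower number a stronger inhibitor:
compound 1 `CC[C@H]1CN(c2ncc(C#N)cc2Cl)CCN1C1CCN(Cc2ccc(Cl)cc2F)CC1` — 50.5 nM
compound 2 `CC[C@H]1CN(c2ncc(-c3nnn[nH]3)cc2Cl)CCN1C1CCN(Cc2ccc(Cl)cc2F)CC1` — 1380 nM

Compound 1 holds the lowest of the two numbers in this assay; its nearest neighbour is compound 2, which lies a 27-fold higher number from compound 1 to compound 2 (1.44 log units; beyond the scatter) away, a large step.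

Compound 3 `CC[C@H]1CN(c2ncc(-c3ncon3)cc2Cl)CCN1C1CCN(Cc2ccc(Cl)cc2F)CC1` is not yet measured. It differs from compound 1 in one place: 1,2,4-oxadiazol-3-yl in place of cyano on an aromatic carbon. Like compound 2, it carries a five-membered aromatic ring with hetero atoms where compound 1 has the cyano group, but the ring is a 1,2,4-oxadiazol-3-yl with 0 hydrogen-bond donors and 3 hydrogen-bond acceptors rather than the 1H-tetrazol-5-yl of compound 2.

For the measured compounds named here, the only step that bears on the change is the one from compound 1 to compound 2, which was large and went to a higher number. A ring in place of cyano at this position is therefore expected to raise the number again, but by less than the tetrazole did, since that ring is not the same one. For compound 3 the step is estimated as a 5.0-fold higher number from compound 1 to compound 3 (0.69 log units; beyond the scatter). The estimate for compound 3 in this assay is 250 nM, with a range from 80 nM to 1000 nM.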

Compound 3, half-maximal inhibitory concentration: 286 nM
For compound 3 the middle estimate is 1.1-fold (0.06 log units) below the measured one; low and high end bracket the measured number.
By their numbers in this assay, from the lowest: compound 1; then compound 3; then compound 2.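

In this assay the aromatic carbon para to a large group does not respond alike to every five-membered aromatic ring: the change gives a 5.7-fold higher number from compound 1 to compound 3 (0.75 log units; beyond the scatter) as a modest step, whereas the 1H-tetrazol-5-yl step from the same cyano compound was large. Exchanging one ring for the other on this carbon gives a 4.8-fold lower number from compound 2 to compound 3 (0.68 log units; beyond the scatter) and so shows that the identity of the ring matters, not only the presence of a ring in place of cyano. Cyano still gives the lowest number of the three, and nothing measured on these groups accompanies the numbers to account for the gap between the two rings.

From the compounds shown here alone, whether a primary carboxamide, a carboxylic acid or a 1,3,4-oxadiazol-2-yl group on this carbon would come closer to cyano than the 1,2,4-oxadiazol-3-yl does remains open. Also open, going by these compounds, is whether the order of cyano, 1,2,4-oxadiazol-3-yl and 1H-tetrazol-5-yl would hold with a methyl group in place of the chloro group.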